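Replacing the ring-nitrogen substituent of compound 2

The source may hold more compounds than are shown below. What is called first, only, known or untested is meant among the compounds shown, and "the series" means these compounds.

Among the measured compounds shown here, compound 2 `NC(=O)c1c(NC(=O)c2ccccc2Cl)sc2c1CCN(C(=O)Nc1ccccc1Cl)C2` is one of two compounds measured in a functional assay on MKN-74 cells (Homo sapiens) for antiproliferative activity, with a stated time of 24 h; a higher number here means a weaker inhibitor, a lower number a stronger inhibitor. In this assay compound 2 gives 16300 nM, the highest of the two numbers; the nearest is compound 1 `N#Cc1ccccc1CN1CCc2c(sc(NC(=O)c3ccccc3Cl)c2C(N)=O)C1`, which in this assay gives 9500 nM. For the measured compounds named here, the only measured step joining them, a 1.7-fold higher number from compound 1 to compound 2 (0.23 log units; within the scatter), shows that exchanging the group on the amine nitrogen in the ring moves the number only within the scatter.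

Compound 3 `Cc1ccccc1NC(=S)N1CCc2c(sc(NC(=O)c3ccccc3Cl)c2C(N)=O)C1` keeps the shared core of compound 2 and differs from it at the same position: a group of 10 heavy atoms (8 carbon, 1 nitrogen, 1 sulfur; one six-membered aromatic ring of carbon only) in place of a group of 10 heavy atoms (7 carbon, 1 nitrogen, 1 oxygen, 1 chlorine; one six-membered aromatic ring of carbon only), on an amine nitrogen in a ring. Going by the values given here, no measured step covers this exact exchange. Among the compounds with values here, the one step that bears on the position, a 1.7-fold higher number from compound 1 to compound 2 (0.23 log units; within the scatter), was small, so the exchange of one ring-nitrogen substituent for another of like size is expected to leave compound 3 close to compound 2, with no step beyond the scatter in either direction. Compound 3 is therefore estimated at 14000 nM in this assay, within a range of 5000 nM to 40000 nM, which corresponds to an expected step of a 1.2-fold lower number from compound 2 to compound 3 (0.07 log units; within the scatter).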

Compound 3, half-maximal inhibitory concentration: 11700 nM
Compound 3: middle estimate off by 1.2-fold (0.08 log units), on the high side; the range from low to high includes it.
By their numbers in this assay, from the lowest: compounds 1, 3 and 2 (each within the scatter of the next).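

In this assay, three different groups have now stood on the amine nitrogen in a ring, and the two new steps, a 1.4-fold lower number from compound 2 to compound 3 (0.14 log units; within the scatter) and a 1.2-fold higher number from compound 1 to compound 3 (0.09 log units; within the scatter), both lie within the scatter, so the three compounds are not separated in this assay. The entering group has sulfur and no oxygen or chlorine, unlike (2-chlorophenyl)carbamoyl, yet it has the same count of heavy atoms, and this exchange, like the earlier one involving 2-cyanobenzyl, gives no step beyond the scatter. No measurement is available to explain why these groups read alike.

On these data alone, all three groups on this nitrogen carry a six-membered aromatic ring of carbon only, so it remains open how the number would respond to a group without that ring, such as a short alkyl chain, an amine or a carboxylic acid. The three compounds also share the rest of their structure, which leaves open how far the number would move with a change anywhere else on the shared core.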